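The source may report more compounds than this note shows. Statements on the series, on what has been measured and on what is new or still open speak of the compounds shown alone.

Measured so far:
compound 1 `COc1ccc(-c2nc(CNc3ccc(C(=O)NO)cc3)n(-c3ccccc3)n2)cc1` — 77.6%
compound 2 `COc1ccc(-n2nc(-c3ccc(O)cc3)nc2CNc2ccc(C(=O)NO)cc2)cc1` — 70.3%

In an assay on Sf9 cells for inhibition of protein deacetylase HDAC6 (Homo sapiens), read by fluorescence, with a stated time of 40 min, tested at 100 nM (on this read-out lower numbers stand for less inhibition and higher numbers for more inhibition at the one concentration tested (going by the name of the read-out)), compound 1 gives 77.6%, the higher of the two numbers; the difference to compound 2, which gives 70.3%, lies within the usual scatter, so the two cannot be told apart. Compound 3 `O=C(NO)c1ccc(NCc2nc(-c3ccc(Cl)c(Cl)c3)nn2-c2ccccc2)cc1` is not yet measured. It differs from compound 1 by 3,4-dichlorophenyl in place of 4-methoxyphenyl on an aromatic carbon. Among the compounds with values here, no step between two measured compounds shows what this change does, so compound 3 is expected to stay near compound 1, with a step of a number 5.6 percentage points lower from compound 1 to compound 3 (within the scatter) not beyond the scatter. Compound 3 is estimated at 72%, between 50% and 90%.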

Compound 3, a percentage reported as inhibition, at one concentration (the size of the read-out at that concentration, not a potency): 34.5%
For compound 3 the middle estimate is 37.5 percentage points above the measured one, outside the stated range (below it).
By their numbers in this assay, from the lowest: compound 3; then compounds 2 and 1 (each within the scatter of the next).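

Within the data shown here, this is the first step that can be read at this position, the aromatic carbon between two ring nitrogen atoms, and it shows that the position is sensitive to the group it carries. In this assay, 3,4-dichlorophenyl in place of 4-methoxyphenyl gives a number 43.1 percentage points lower from compound 1 to compound 3 (beyond the scatter), a large change although both groups have the same heavy-atom count. Nothing measured here bears on why the number falls.

The compounds shown do not separate losing the methoxy group from gaining the two chlorine atoms. From the compounds shown here alone, how a plain phenyl or a 4-chlorophenyl would read at this position remains open.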